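Amino in Place of Chloro on Compound 1

The source may hold more compounds than are shown below. What is called first, only, known or untested is meant among the compounds shown, and "the series" means these compounds.

Compound 1 `ClCc1ccccc1Cn1cnc2c(Cl)nc(Cl)nc21` holds the lowest of the two numbers: in a functional assay on MDA-MB-231 cells (Homo sapiens) for cytotoxicity, read by sulforhodamine B assay, with a stated time of 48 h (on this read-out higher numbers stand for weaker inhibition of growth and lower numbers for stronger inhibition of growth), compound 1 gives 330 nM, whereas compound 2 `ClCc1ccccc1Cn1cnc2ncnc(Cl)c21` gives 2750 nM, a gap beyond the scatter. Compound 3 `Nc1nc(Cl)c2ncn(Cc3ccccc3CCl)c2n1` differs from compound 1 by amino in place of chloro on an aromatic carbon. Among the compounds with values here, no measured pair shows this change. A modest loss is expected, because compound 2 reaches 2750 nM while compound 1 gives 330 nM. For compound 3 the step of a 2.7-fold higher number from compound 1 to compound 3 (0.44 log units; beyond the scatter) is expected to be a small rise. Compound 3 is estimated at 900 nM, between 300 nM and 3000 nM.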

Compound 3, concentration for 50% growth inhibition: 2950 nM
Beside the measured number, compound 3's estimate is 3.3-fold (0.52 log units) below it, and the stated range covers the measured number.
By their numbers in this assay, from the lowest: compound 1; then compounds 2 and 3 (each within the scatter of the next).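

Amino in place of chloro on an aromatic carbon between two ring nitrogen atoms gives an 8.9-fold higher number from compound 1 to compound 3 (0.95 log units; beyond the scatter) in this assay, the first direct reading of this change, and it shows that growth inhibition here responds to which of these two groups the position carries. Nothing measured explains the rise.

The compounds shown leave open whether the loss follows from gaining amino or from losing chloro. A methoxy or methylamino group at this position would bear on that question.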